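A few compounds are considered here, and "the series" means these few. Any claim that something is new, unique, unknown or untested is made for them only; others in the source may bear on it.

Measured compounds in a functional assay on MDA-MB-231 cells (Homo sapiens) for antiproliferative activity, read by CCK-8 assay, with a stated time of 72 h; on this read-out higher numbers stand for weaker inhibition and lower numbers for stronger inhibition:
- compound 1 `CC1=NN(c2ccc(C)cc2)C(=O)C12C=CC(=O)C=C2c1cccc(C)c1`: 19400 nM
- compound 2 `CC1=NN(c2ccc(C)cc2)C(=O)C12C=CC(=O)C=C2c1ccc(C)cc1`: 5110 nM
- compound 3 `CC1=NN(c2ccc(Cl)cc2)C(=O)C12C=CC(=O)C=C2c1ccc(C)cc1`: 14300 nM

Compound 2 holds the lowest number of the three. Two single changes lead away from it. In this assay a 3.8-fold higher number from compound 2 to compound 1 (0.58 log units; beyond the scatter); the change is 3-methylphenyl in place of 4-methylphenyl on a double-bonded ring carbon. Also a 2.8-fold higher number from compound 2 to compound 3 (0.45 log units; beyond the scatter); the change here is chloro in place of methyl on an aromatic carbon. Compounds 1 and 3 sit within the scatter of each other.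

Compound 4 `CC1=NN(c2ccc(Cl)cc2)C(=O)C12C=CC(=O)C=C2c1cccc(C)c1` is not yet measured. It differs from compound 3 in one place: 3-methylphenyl in place of 4-methylphenyl on a double-bonded ring carbon. This is the same change that was made from compound 2 to compound 1, on a core that differs by chloro in place of methyl on an aromatic carbon, and the place where it is made reads the same in both cases. Among the compounds with values here, only one measured pair carries this change, so the expectation rests on that pair alone and is open to the usual scatter.

For compound 4 the estimated step is a 3.1-fold higher number from compound 3 to compound 4 (0.50 log units; beyond the scatter), taken from compound 1 and compound 2, where a 3.8-fold higher number from compound 2 to compound 1 (0.58 log units; beyond the scatter). Compound 4 is therefore expected to give about 45000 nM in this assay, with a range from 18000 nM to 110000 nM.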

Compound 4, half-maximal inhibitory concentration: 26900 nM
Compound 4: middle estimate off by 1.7-fold (0.22 log units), on the high side, within the range that was stated.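

In this assay, 3-methylphenyl in place of 4-methylphenyl on the chloro core gives a 1.9-fold higher number from compound 3 to compound 4 (0.27 log units; within the scatter), and the change agrees across the two cores within the scatter: the same change on two cores in this assay, a 3.8-fold higher number (0.58 log units; beyond the scatter) from compound 2 to compound 1 and a 1.9-fold higher number (0.27 log units; within the scatter) from compound 3 to compound 4, 2.0-fold (0.30 log units) apart, within the scatter of two such steps. Chloro in place of methyl on the core bearing 3-methylphenyl gives a 1.4-fold higher number from compound 1 to compound 4 (0.14 log units; within the scatter), and this change also agrees across the two cores within the scatter: the same change on two cores in this assay, a 2.8-fold higher number (0.45 log units; beyond the scatter) from compound 2 to compound 3 and a 1.4-fold higher number (0.14 log units; within the scatter) from compound 1 to compound 4, 2.0-fold (0.30 log units) apart, within the scatter of two such steps. Both comparisons rest on the same four compounds and so form a single check, which does not fix the size of either change and does not show that either change would carry over to other cores, and the steps into compound 4 do not, taken alone, separate from the scatter.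

Still open, going by these compounds, is how other groups behave on the two aromatic rings, such as a methoxy, a trifluoromethyl or an amine in place of the methyl or chloro. Also open, on these data alone, is whether a longer chain in place of the methyl on the shared core would keep the same steps.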